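The source may hold more compounds than are shown below. What is called first, only, known or untested is meant among the compounds shown, and "the series" means these compounds.

Four compounds share one core and differ only in the group on a saturated ring carbon. Compound 1 `C=CC[C@@H]1CN[C@H](C(=O)N2CCC[C@H]2C#N)C1` carries allyl there, and in an assay on the whole organism (plasma, strain Sprague-Dawley) for inhibition of Dipeptidyl peptidase 4 (Rattus norvegicus), with a stated time of 6 h, at a dose of 1 mg/kg by the oral route (on this read-out lower numbers stand for less inhibition and higher numbers for more inhibition at the one dose given (going by the name of the read-out)), compound 1 gives 38%. Compound 2 `CCN(CC)C(=O)[C@@H]1CN[C@H](C(=O)N2CCC[C@H]2C#N)C1` carries diethylcarbamoyl; in this assay compound 2 gives 43%, and the step of a number 5 percentage points higher from compound 1 to compound 2 (within the scatter) stays within the scatter. Compound 3 `N#C[C@@H]1CCCN1C(=O)[C@@H]1C[C@H](C(=O)N2CCC2)CN1` carries (azetidin-1-yl)carbonyl; in this assay compound 3 gives 77%, the highest of the three numbers and beyond the scatter from both others, as the steps of a number 39 percentage points higher from compound 1 to compound 3 (beyond the scatter) and a number 34 percentage points higher from compound 2 to compound 3 (beyond the scatter) show.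

Compound 4 `CNC(=O)[C@@H]1CN[C@H](C(=O)N2CCC[C@H]2C#N)C1` is still to be measured. Its change from compound 3 is methylamino in place of azetidin-1-yl on a carbonyl carbon. Among the compounds with values here, the one measured step at the carbonyl carbon is a number 34 percentage points higher from compound 2 to compound 3 (beyond the scatter), which shows that exchanging one group on that carbonyl for another can shift the read-out by a large amount. Methylamino has no precedent among the measured compounds, and the one step available runs from diethylamino to azetidin-1-yl, not from azetidin-1-yl onward, so the direction is open. A downward step of moderate size from the high value of the azetidine amide is expected: a number 22 percentage points lower from compound 3 to compound 4 (beyond the scatter). Compound 4 is estimated at 55%, with a range from 30% to 80%.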

Compound 4, a percentage reported as inhibition, in the whole organism at one dose (the size of the read-out at that dose, not a potency): 75%
Beside the measured number, compound 4's estimate is 20 percentage points below it, within the range that was stated.
By their numbers in this assay, from the lowest: compounds 1 and 2 (each within the scatter of the next); then compounds 4 and 3 (each within the scatter of the next).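

With a number 2 percentage points lower from compound 3 to compound 4 (within the scatter) in this assay, the ring of azetidin-1-yl is not needed to hold the read-out at this carbonyl carbon, since open-chain methylamino serves as well; before this result, only the azetidine amide stood at the high level. The step of a number 32 percentage points higher from compound 2 to compound 4 (beyond the scatter) is large and shows that an open-chain amine on the carbonyl carbon does not in itself lower the read-out, so among these amides compound 2 is the one that stands apart, and a number 37 percentage points higher from compound 1 to compound 4 (beyond the scatter) adds a second amide clear of allyl, although the carbamoyl of compound 2 goes against any rule that an amide at the saturated ring carbon suffices. No measurement at hand accounts for the separation of diethylamino from methylamino and azetidin-1-yl.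

Open, on these data alone, is where, among amines on this carbonyl carbon, the read-out falls away: dimethylamino, ethylamino and pyrrolidin-1-yl would place that point between methylamino and diethylamino. Also open, as far as these compounds go, is whether the amide is needed at all at the saturated ring carbon, which a carboxylic acid or an aminomethyl group there would test.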